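The source may report more compounds than this note shows. Statements on the series, on what has been measured and on what is new or still open speak of the compounds shown alone.

In a functional assay on MV4-11 cells (Homo sapiens) for antiproliferative activity, read by CellTiter-Glo, with a stated time of 72 h (on this read-out lower numbers stand for stronger inhibition of growth and higher numbers for weaker inhibition of growth), compound 1 `CC(C)(C)OC(=O)Nc1nc(-c2cc(F)ncc2Cl)cs1` gives > 10000 nM as a limit, not a number. Compound 2 `Fc1cc(-c2csc(NCC3CCOCC3)n2)c(Cl)cn1` gives > 10000 nM as a limit too. Compound 3 `COCCNc1cc(-c2csc(NCC3CCOCC3)n2)c(Cl)cn1` also gives > 10000 nM as a limit, so no number places it. The evidence so far is the limit of > 10000 nM in this assay, at which 3 of the 3 values shown sit, and nothing finer. Compound 4 `O=C(Nc1cc(-c2csc(NCC3CCOCC3)n2)c(Cl)cn1)c1ccc(F)cc1` has (4-fluorophenyl)carbonyl in place of 2-methoxyethyl on a nitrogen on an aromatic ring, a difference of (4-fluorophenyl)carbonyl in place of 2-methoxyethyl on a nitrogen on an aromatic ring at that nitrogen. The measured changes offer a step that the two limits leave unreadable from compound 1 to compound 2 and a step that the two limits leave unreadable from compound 2 to compound 3 with no size to carry over. With so large a swap, some gain in growth inhibition is expected, though compound 4 may also stay at the limit. The expected change is an at least 5.0-fold lower number from compound 3 to compound 4 (0.69 log units; beyond the scatter) toward stronger inhibition, a cautious estimate. Compound 4 is estimated at 2000 nM within a range of 150 nM to 10000 nM in this assay for now.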

Compound 4, concentration for 50% growth inhibition: 550 nM
For compound 4 the middle estimate is 3.6-fold (0.56 log units) above the measured one; the measured number falls inside the stated range.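

Among these compounds, compound 4 is the first compound here with a number rather than a limit in this assay, so this nitrogen is the first place where a change has a readable size: the limit of > 10000 nM in this assay, at which 3 of the 4 values shown sit. Putting (4-fluorophenyl)carbonyl in place of 2-methoxyethyl gives an at least 18-fold lower number from compound 3 to compound 4 (1.25 log units; beyond the scatter), and the swap of ((4-fluorophenyl)carbonyl)amino for fluoro gives an at least 18-fold lower number from compound 2 to compound 4 (1.25 log units; beyond the scatter). The two earlier steps cannot be read.

The compounds shown do not separate the carbonyl from the 4-fluorophenyl ring. On these data alone, how an unsubstituted benzoyl or a small acetyl group on this nitrogen would read stays open.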